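Oxazoline to thiazoline swap on the sulfonylmethyl side chain

This account rests on a few compounds, and the source may have more. Where it says the series, first, only, none or still open, it means among the compounds named here.

Within the data shown here, compound 2 `O=S(=O)(CC1=NCCO1)C1C(c2ccccc2)=NOC1c1ccccc1` gives 51.7% in a functional assay, tested at 50 ug/mL (a higher number here means a stronger effect of the compound at the concentration tested, a lower number a weaker effect), and holds the only number in this set; compound 1 `O=S(=O)(CC1=NCCS1)c1c(-c2ccccc2)nn(-c2ccccc2)c1-c1ccccc1` gave only "not active" (no number reported) in this assay with no number. Compound 3 `O=S(=O)(CC1=NCCS1)C1C(c2ccccc2)=NOC1c1ccccc1` is not yet measured. The change from compound 2 to compound 3 is a group of 5 heavy atoms (3 carbon, 1 nitrogen, 1 sulfur; one five-membered non-aromatic ring with 2 hetero atoms) in place of a group of 5 heavy atoms (3 carbon, 1 nitrogen, 1 oxygen; one five-membered non-aromatic ring with 2 hetero atoms), on a saturated chain carbon bound to a sulfonyl sulfur. Among the measured compounds shown here, no step between measured compounds is available, so the expected step from compound 2 to compound 3 in this assay is a number 6.7 percentage points lower from compound 2 to compound 3 (within the scatter), a small decrease that may not exceed the scatter. Compound 3 is estimated at 45%, within 20% to 70%.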

Compound 3, a percentage reported as activity, at one concentration (the size of the read-out at that concentration, not a potency): "not active" (no number reported)
For compound 3 the study gives words and no number, so the estimate cannot be set against anything.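

In this assay, among these compounds, compound 3 gives "not active" (no number reported) and no step from compound 2 to compound 3 can be read. The size of the effect of this ring exchange stays open, and no measurement shown bears on a reason.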